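The compounds below may be only part of what the source reports. "The series", "measured", "known", "first", "only" and "open" are said of these compounds alone.

Measured compounds:
- compound 1, `C/C(=N\NC(=O)c1ccc(C(F)(F)F)cc1)c1cnccn1` — 1160 nM
- compound 2, `Nc1ccc(C(=O)NN=C(c2ccccn2)c2ccccn2)cc1` — 7640 nM
- compound 3, `C/C(=N\NC(=O)c1ccncc1)c1cnccn1` — 5790 nM

All three were tested in an ADME assay on cells (Homo sapiens) for antiproliferative activity, read by MTT assay; on this read-out lower numbers stand for stronger inhibition and higher numbers for weaker inhibition. Compound 1 stands at the lowest number of the three, with compound 3 the nearest to it and compound 2 the furthest; both of those gaps are beyond the usual scatter, so compound 1 shows the strongest inhibition of this small set. Among the compounds with values here, no two measured compounds differ from each other in only one place, so there is no single-change step within the measured set to lean on.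

Compound 4, `C/C(=N\NC(=O)c1ccc(O)cc1)c1cnccn1`, has not yet been measured in this assay. It differs from compound 1 in one place: hydroxy in place of trifluoromethyl on an aromatic carbon. Because compound 1 gives 1160 nM, the starting point is the best number seen so far, and the other two compounds carry different ring and amide patterns that do not isolate this change. With nothing to anchor the size of the move, the expectation is that the step from compound 1 to compound 4 , a 2.6-fold higher number from compound 1 to compound 4 (0.41 log units; beyond the scatter), is modest and toward a higher number, though a change within the scatter is possible. Compound 4 is therefore estimated at 3000 nM, with a range from 900 nM to 12000 nM.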

Compound 4, half-maximal inhibitory concentration: 16800 nM
The estimate for compound 4 lay 5.6-fold (0.75 log units) below the measured number; measured number outside the range, above it.
By their numbers in this assay, from the lowest: compound 1; then compounds 3 and 2 (each within the scatter of the next); then compound 4.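

In this assay, putting hydroxy in place of trifluoromethyl on an aromatic carbon para to a large group gives a 14-fold higher number from compound 1 to compound 4 (1.16 log units; beyond the scatter), a large step well beyond the usual scatter. Within the data shown here, this is the first comparison in the set where only one place changes and the rest of the molecule stays the same, so it shows that the group at this position has a strong bearing on the number, which the earlier compounds could not show. The two groups differ at once in their heavy atoms and in their hydrogen-bond donors and acceptors, and nothing measured here tells which of these differences matters.

The compounds shown leave open how other groups at this same place would read, such as methoxy, chlorine or a carboxylic acid, and so whether trifluoromethyl is unusually favourable or hydroxy unusually unfavourable. They also leave open whether this change would give a step of similar size on a different core, since it has been seen only once, on the core of compound 1.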